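Sulfonamide series: acyl variation on the pyrrolidine amide

A few compounds are considered here, and "the series" means these few. Any claim that something is new, unique, unknown or untested is made for them only; others in the source may bear on it.

Measured so far in a functional assay on U2OS cells for antagonist activity at proto-oncogene Wnt-3 (Homo sapiens), read by a luciferase reporter, with a stated time of 18 h; a lower number here means that less compound is needed, a higher number that more compound is needed for the effect:
- compound 1 `O=C(CN1CCCC1)N1CCC(NS(=O)(=O)c2cc(S(=O)(=O)c3ccccc3)ccc2C(F)(F)F)CC1` gives 190 nM
- compound 2 `CC(C)(C)C(=O)N1CCC[C@H]1C(=O)N1CCC(NS(=O)(=O)c2cc(S(=O)(=O)c3ccccc3)ccc2C(F)(F)F)CC1` gives 270 nM

Among the measured compounds shown here, on these two numbers compound 2 stands at the higher end, with compound 1 as its only neighbour; the step of a 1.4-fold higher number from compound 1 to compound 2 (0.15 log units; within the scatter) is within the scatter, so the two values cannot be ordered.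

Compound 3 `CC(C)(C)CC(=O)N1CCC[C@H]1C(=O)N1CCC(NS(=O)(=O)c2cc(S(=O)(=O)c3ccccc3)ccc2C(F)(F)F)CC1` is not yet measured. It differs from compound 2 by neopentyl in place of tert-butyl on a carbonyl carbon; cut one bond further out, the change reads (tert-butyl)carbonyl to neopentylcarbonyl.

For the measured compounds named here, only one measured step is at hand, and it changes a different part of the acyl side of the shared core; a 1.4-fold higher number from compound 1 to compound 2 (0.15 log units; within the scatter) was within the scatter. Going by the values given here, no measured pair shows the tert-butyl to neopentyl exchange itself, so the expectation for compound 3 in this assay rests on the absence of any movement beyond the scatter when the group on that carbonyl carbon was last varied. The expected step of a 1.1-fold higher number from compound 2 to compound 3 (0.05 log units; within the scatter) is therefore within the scatter, in no particular direction. Compound 3 is estimated at 300 nM, with a range of 120 nM to 750 nM.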

Compound 3, half-maximal effective concentration: 120 nM
The estimate for compound 3 lay 2.5-fold (0.40 log units) above the measured number; the measured number falls inside the stated range.
By their numbers in this assay, from the lowest: compounds 3, 1 and 2 (each within the scatter of the next, the first and the last beyond it).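

In this assay, among the compounds shown here, the exchange of tert-butyl for neopentyl on the carbonyl carbon gives a 2.3-fold lower number from compound 2 to compound 3 (0.35 log units; beyond the scatter) and is the first step to leave the scatter, so the group at this position is not indifferent to a change as small as this one. The wider replacement of (pyrrolidin-1-yl)methyl by 1-(neopentylcarbonyl)pyrrolidin-2-yl gives a 1.6-fold lower number from compound 1 to compound 3 (0.20 log units; within the scatter) and therefore does not separate the two compounds, which means the neopentyl group brings the acylated pyrrolidine side level with the simpler side chain of compound 1 but cannot be said to surpass it. No measurement at hand bears on why the neopentyl and tert-butyl groups differ in this way.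

Going by these compounds, the tert-butyl to neopentyl exchange rests on a single pair of modest size, so it is open whether the number keeps falling with a longer chain such as n-hexyl on this carbonyl carbon or whether neopentyl is already the end of the trend. Equally open, on these data alone, is how this position responds to a group of a different kind, such as a primary amine or a carboxylic acid, in place of the neopentyl group.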